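The source may hold more compounds than are shown below. What is called first, only, known or untested is meant among the compounds shown, and "the series" means these compounds.

Compound 1 `COc1ccc(N2CCN(c3nc(C(F)(F)F)ccc3CNC(=O)C(C)c3ccc(NS(C)(=O)=O)c(F)c3)CC2)cc1` gives 2.5 nM in a functional assay on CHO-K1 cells for antagonist activity at transient receptor potential cation channel subfamily V member 1 (Homo sapiens), read by FLIPR; on this read-out higher numbers stand for weaker inhibition and lower numbers for stronger inhibition.
Compound 2 `CC(C(=O)NCc1ccc(C(F)(F)F)nc1N1CCN(c2ncccc2Cl)CC1)c1ccc(NS(C)(=O)=O)c(F)c1` gives 2.1 nM in this assay.

On these two numbers compound 2 and compound 1 sit within the scatter of each other, the step from compound 1 to compound 2 being a 1.2-fold lower number from compound 1 to compound 2 (0.08 log units; within the scatter). Compound 3 `CC(C(=O)NCc1ccc(C(F)(F)F)nc1N1CCN(c2ncccc2C(F)(F)F)CC1)c1ccc(NS(C)(=O)=O)c(F)c1` differs from compound 2 by trifluoromethyl in place of chloro on an aromatic carbon. Among the measured compounds shown here, no measured step touches this group directly; the one measured step exchanged the whole ring that carries it and stayed within the scatter, so nothing here points to a shift beyond the scatter in this assay. Compound 3 is therefore expected to give about 2.5 nM (range 0.8 nM to 8 nM), a step of a 1.2-fold higher number from compound 2 to compound 3 (0.08 log units; within the scatter).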

Compound 3, inhibition constant: 2.8 nM
Compound 3: the middle estimate sits 1.1-fold (0.05 log units) below what was measured, and the stated range covers the measured number.
By their numbers in this assay, from the lowest: compounds 2, 1 and 3 (each within the scatter of the next).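

On the six-membered aromatic ring with 1 nitrogen, the carbon ortho to a large group takes trifluoromethyl in place of chloro, 4 heavy atoms for 1, without a shift beyond the scatter in this assay (a 1.3-fold higher number from compound 2 to compound 3 (0.12 log units; within the scatter)). The earlier step exchanged the whole ring, whereas this one changes only the group on that carbon. The 3-(trifluoromethyl)pyridin-2-yl ring also stays within the scatter when set against 4-methoxyphenyl (a 1.1-fold higher number from compound 1 to compound 3 (0.05 log units; within the scatter)).

No evidence given here accounts for this flat result. Going by these compounds, whether an amine or a carboxylic acid on this carbon would keep the number within the scatter stays open.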